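The source may report more compounds than this note shows. Statements on the series, on what has been measured and on what is new or still open speak of the compounds shown alone.

The measured compounds:

compound 1, `CCCCNC(=S)NC1=C(C#N)C(c2ccc(Cl)cc2Cl)C2=C(CCCC2=O)N1c1ccc(S(N)(=O)=O)cc1`, 30%
compound 2, `N#CC1=C(NC(=O)CCC(=O)O)N(c2ccc(S(N)(=O)=O)cc2)C2=C(C(=O)CCC2)C1c1ccc(Cl)cc1Cl`, 20%

Both were examined in a functional assay on Ehrlich cells (Mus musculus) for cytotoxicity, read by trypan blue exclusion, with a stated time of 2 h, tested at 10 ug/mL; a lower number here means a weaker effect, a higher number a stronger effect of the compound at the concentration tested. In this assay compound 1 gives 30%, and compound 2 gives 20%. For the measured compounds named here, compound 2 holds the smaller of the two numbers, but the only step that reaches it, a number 10 percentage points lower from compound 1 to compound 2 (within the scatter), lies within the scatter, so the two compounds cannot be told apart on these data.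

Compound 3, `N#CC1=C(N2C(=O)CCC2=O)N(c2ccc(S(N)(=O)=O)cc2)C2=C(C(=O)CCC2)C1c1ccc(Cl)cc1Cl`, has not yet been measured. It differs from compound 2 in one place: 2,5-dioxopyrrolidin-1-yl in place of ((2-carboxyethyl)carbonyl)amino on a double-bonded ring carbon. Going by the values given here, only one measured step bears on this change, a number 10 percentage points lower from compound 1 to compound 2 (within the scatter), which also altered the group on that part of the shared core, and it did not move the read-out beyond the scatter. On this single step there is no ground to expect a shift in either direction, and the change from compound 2 to compound 3 is therefore expected to give a number 5 percentage points higher from compound 2 to compound 3 (within the scatter), a step within the scatter. For compound 3 the value in this assay is estimated at 25%, with a range from 10% to 45%.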

Compound 3, a percentage reported as activity, at one concentration (the size of the read-out at that concentration, not a potency): 20%
The estimate for compound 3 lay 5 percentage points above the measured number; the range from low to high includes it.
By their numbers in this assay, from the lowest: compounds 2, 3 and 1 (each within the scatter of the next).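

In this assay, setting 2,5-dioxopyrrolidin-1-yl in place of ((2-carboxyethyl)carbonyl)amino on the double-bonded ring carbon gave no change at the digits printed from compound 2 to compound 3 (within the scatter), so at this position a group with one five-membered non-aromatic ring and 0 hydrogen-bond donors could not be told apart from an open group with no ring and 2 hydrogen-bond donors. For the compounds shown here, the thiourea-bearing group of compound 1 gives the same picture against the ring group, with a number 10 percentage points lower from compound 1 to compound 3 (within the scatter), so three different groups at this one place now fall within the scatter of each other in this assay, where the earlier pair offered only a single step between open chains. No measurement is at hand that could account for this absence of a difference.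

What the compounds shown leave open is whether any group at this position can move the read-out beyond the scatter, for instance a free amine, a longer chain ending in a carboxylic acid, or a six-membered ring in place of the five-membered one. They also leave open what the 2,4-dichlorophenyl and 4-sulfamoylphenyl groups contribute, since both stay the same throughout.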